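Exchanging bromo for (4-methylpiperazin-1-yl)methyl

The source may report more compounds than this note shows. Statements on the series, on what has been measured and on what is new or still open speak of the compounds shown alone.

compound 1 `CC(C)(C)OC(=O)N1CCCN(CCCCCOc2c(Br)cc(Br)cc2Oc2ccc(Br)cc2Br)CC1`: 44.8 ug/mL
compound 2 `BrCCCOc1c(Br)cc(Br)cc1Oc1ccc(Br)cc1Br`: 29.9 ug/mL
compound 3 `BrCCCCOc1c(Br)cc(Br)cc1Oc1ccc(Br)cc1Br`: 25.9 ug/mL

In a functional assay on HL-60 cells (Homo sapiens) for cytotoxicity, read by MTT assay, with a stated time of 24 h (on this read-out higher numbers stand for weaker inhibition and lower numbers for stronger inhibition), compound 3 gives 25.9 ug/mL, which is within the scatter of the other two values, so the three compounds show no order. Compound 4 `CN1CCN(CCCCCOc2c(Br)cc(Br)cc2Oc2ccc(Br)cc2Br)CC1` is reached from compound 3 through ((4-methylpiperazin-1-yl)methyl in place of bromo on a saturated chain carbon, four bonds along the chain from an oxygen on an aromatic ring). Going by the values given here, the only measured step, a 1.2-fold lower number from compound 2 to compound 3 (0.06 log units; within the scatter), involves a far smaller change. Compound 1, with no bromo on a saturated chain carbon, gives 44.8 ug/mL, also within the scatter of compound 3. Among the compounds with values here, no measured step covers this exchange, so the expectation remains loose. The expected change is a 1.0-fold lower number from compound 3 to compound 4 (0.02 log units; within the scatter), none beyond the scatter. For compound 4 the estimated value is 25 ug/mL, with an expected range from 10 ug/mL to 50 ug/mL.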

Compound 4, half-maximal inhibitory concentration: 48.3 ug/mL
Compound 4: the middle estimate sits 1.9-fold (0.29 log units) below what was measured, within the range that was stated.
By their numbers in this assay, from the lowest: compounds 3, 2, 1 and 4 (each within the scatter of the next).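

In this assay, (4-methylpiperazin-1-yl)methyl in place of bromo on a saturated chain carbon gives a 1.9-fold higher number from compound 3 to compound 4 (0.27 log units; within the scatter), and 2-(4-methylpiperazin-1-yl)ethyl in place of bromo gives a 1.6-fold higher number from compound 2 to compound 4 (0.21 log units; within the scatter). At this chain end, then, even a group carrying a six-membered non-aromatic ring gives no step beyond the scatter, whereas the earlier step covered only bromo against bromomethyl. Nothing available bears on why this is so. On these data alone, whether a primary amine or a carboxylic acid at the end of the chain would give a larger step remains open.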